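Ring isomer step on the alkyne arm, compound 2 to 3

The source may hold more compounds than are shown below. What is called first, only, known or untested is meant among the compounds shown, and "the series" means these compounds.

Measured so far:
compound 1 `C#Cc1cncc(C#Cc2ccc3ncn(-c4ccnc(N)n4)c3c2)c1` gives 63100 nM
compound 2 `C#Cc1cc(C#Cc2ccc3ncn(-c4ccnc(N)n4)c3c2)ncn1` gives 50100 nM
compound 3 `C#Cc1cnc(C#Cc2ccc3ncn(-c4ccnc(N)n4)c3c2)nc1` not yet measured

Two compounds have been run in an assay on Sf9 cells for inhibition of mitogen-activated protein kinase kinase kinase 14 variant S549D (Homo sapiens), with a stated time of 30 min, in the presence of a further agent that is not named here; a higher number here means a weaker inhibitor, a lower number a stronger inhibitor. Both are weak, and they are within the scatter of each other: a 1.3-fold lower number from compound 1 to compound 2 (0.10 log units; within the scatter). Compound 2 has the lower of the two numbers, but the gap to compound 1 does not amount to a difference. Compound 2 is therefore the only reference point for the next step.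

Compound 3 differs from compound 2 in one place: a group of 8 heavy atoms (6 carbon, 2 nitrogen; one six-membered aromatic ring with 2 hetero atoms) in place of a group of 8 heavy atoms (6 carbon, 2 nitrogen; one six-membered aromatic ring with 2 hetero atoms), on a triple-bonded carbon. The two have the same atoms, joined differently; the ring that enters has the same count of carbon and nitrogen as the ring that leaves.

For the measured compounds named here, one measured step bears on this: from compound 1 to compound 2 a ring of the same size was exchanged on the same triple-bonded carbon, and that step stayed within the scatter (a 1.3-fold lower number from compound 1 to compound 2 (0.10 log units; within the scatter)). Nothing in the two numbers suggests that the arrangement of atoms within this ring moves the read-out. For compound 3 the expected step from compound 2 is a 1.0-fold lower number from compound 2 to compound 3 (0.00 log units; within the scatter), no change beyond the scatter. The estimate for compound 3 is 50000 nM, with a range from 20000 nM to 125000 nM.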

Compound 3, half-maximal inhibitory concentration: 25100 nM
For compound 3 the middle estimate is 2.0-fold (0.30 log units) above the measured one, and the stated range covers the measured number.
By their numbers in this assay, from the lowest: compounds 3, 2 and 1 (each within the scatter of the next, the first and the last beyond it).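

In this assay the exchange of ring groups on the triple-bonded carbon gives its first step beyond the scatter, a 2.5-fold lower number from compound 1 to compound 3 (0.40 log units; beyond the scatter) and that step is modest. The exchange between the two isomeric rings gives a 2.0-fold lower number from compound 2 to compound 3 (0.30 log units; within the scatter) and so does not clearly separate them, which leaves any effect of the arrangement of atoms within the ring unresolved at this level of scatter. A rise in the count of ring hetero atoms does not by itself sort the series: compound 3 goes with such a pattern, but compound 2 goes against it, with the same ring composition as compound 3 and a number still within the scatter of compound 1.

As far as these compounds go, all three compounds carry a six-membered aromatic ring with a triple bond outside it at this place, so it remains open whether an amine, a carboxylic acid or a longer chain on this triple-bonded carbon would shift the number further. No measurement at hand accounts for the steps between these ring groups.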